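Bromo in Place of Trifluoromethyl: an Expected Potency

The source may report more compounds than this note shows. Statements on the series, on what has been measured and on what is new or still open speak of the compounds shown alone.

Measured in a functional assay on A549 cells (Homo sapiens) for antiproliferative activity, read by MTT assay, with a stated time of 72 h; a higher number here means a weaker inhibitor, a lower number a stronger inhibitor:
Compound 1 `COc1cc2ncnc(Nc3ccc(C)cc3)c2cc1OCCCCC(=O)Nc1ccc(S(N)(=O)=O)cc1`: > 40000 nM
Compound 2 `NS(=O)(=O)c1ccc(NC(=S)Nc2ccc3ncnc(Nc4cccc(C(F)(F)F)c4)c3c2)cc1`: 10100 nM

Compound 1 reaches only a limit of this assay, namely (the limit of > 40000 nM in this assay, at which 1 of the 2 values shown sits). Within the data shown here, compound 2 is therefore the only compound with a true number in this assay, and nothing here lets its value be set against another measured one.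

Compound 3 `NS(=O)(=O)c1ccc(NC(=S)Nc2ccc3ncnc(Nc4cccc(Br)c4)c3c2)cc1` differs from compound 2 in one place: bromo in place of trifluoromethyl on an aromatic carbon. Among the measured compounds shown here, no measured pair shows what a change of this kind does here, so the size of the step can only be guessed. A step no larger than the usual scatter, in either direction, is expected from compound 2 to compound 3, which would leave compound 3 close to compound 2 in this assay.

Compound 3 is thus expected to give 8000 nM in this assay, with a plausible range from 2500 nM to 25000 nM, meaning an expected step of a 1.3-fold lower number from compound 2 to compound 3 (0.10 log units; within the scatter).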

Compound 3, half-maximal inhibitory concentration: 25000 nM
Estimate against measurement, compound 3: 3.1-fold (0.49 log units) below, within the range that was stated.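

Among these compounds, this pair gives the first real comparison, since compound 1 differs in more than one place and reaches only a limit. In this assay, bromo in place of trifluoromethyl gives a 2.5-fold higher number from compound 2 to compound 3 (0.39 log units; beyond the scatter), a modest weakening that shows this aromatic carbon is sensitive to the group it carries, even though neither group has hydrogen-bond donors or acceptors. Nothing measured here accounts for the direction of this step.

One pair cannot show whether an amine or a carboxylic acid on the same aromatic carbon would lower the number or raise it further. It also leaves open whether bromo in place of trifluoromethyl would have a similar effect on a different core or with a different linker.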